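Pyrazole series at EP1 binding: carbamate in place of amide

The compounds below may be only part of what the source reports. "The series", "measured", "known", "first", "only" and "open" are said of these compounds alone.

Measured so far:
compound 1 `Cc1cc(C(=O)NCc2ccccn2)nn1Cc1cc(Cl)ccc1OCc1ccccc1`, 25.1 nM
compound 2 `Cc1cc(NC(=O)C2CCCC2)nn1Cc1cc(Cl)ccc1OCc1ccccc1`, 15.9 nM
compound 3 `Cc1cc(NC(=O)C2CCCC2)nn1Cc1cc(Cl)ccc1OCC(C)C`, 25.1 nM

In an assay on CHO-K1 cells for displacement of a labelled ligand from prostaglandin E2 receptor EP1 subtype (Homo sapiens) (a higher number here means a weaker inhibitor, a lower number a stronger inhibitor), compound 1 stands level with compound 3 at the digits shown, the two together the highest of the three numbers; its only other neighbour is compound 2, reached by a 1.6-fold lower number from compound 1 to compound 2 (0.20 log units; within the scatter). Compound 4 `COC(=O)Nc1cc(C)n(Cc2cc(Cl)ccc2OCc2ccccc2)n1` differs from compound 1 at the aromatic carbon of the five-membered aromatic ring: (methoxycarbonyl)amino in place of ((pyridin-2-yl)methyl)carbamoyl on an aromatic carbon. Within the data shown here, the one measured step at that place, a 1.6-fold lower number from compound 1 to compound 2 (0.20 log units; within the scatter), stayed within the scatter; a 1.6-fold higher number from compound 2 to compound 3 (0.20 log units; within the scatter) concerns the group on the oxygen and says nothing here. No step beyond the scatter is therefore expected, with the smaller entering group allowed a slight rise in the number, a 1.6-fold higher number from compound 1 to compound 4 (0.20 log units; within the scatter). For compound 4 the estimate is 40 nM, within 12 nM to 130 nM.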

Compound 4, half-maximal inhibitory concentration: 200 nM
For compound 4 the middle estimate is 5.0-fold (0.70 log units) below the measured one; the whole stated range lies below it.
By their numbers in this assay, from the lowest: compounds 2, 1 and 3 (each within the scatter of the next); then compound 4.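

In this assay, the aromatic carbon of the five-membered ring proves sensitive to its substituent: (methoxycarbonyl)amino in place of ((pyridin-2-yl)methyl)carbamoyl gives an 8.0-fold higher number from compound 1 to compound 4 (0.90 log units; beyond the scatter), unlike the earlier step at this place. Methoxy in place of cyclopentyl on the carbonyl carbon gives a 13-fold higher number from compound 2 to compound 4 (1.10 log units; beyond the scatter), so the group on that carbonyl also matters. Nothing shown accounts for either step.

On these data alone, it remains open whether the carbamate oxygen or the smaller methoxy group drives the rise. A cyclopentyloxy group or a methyl group on that carbonyl carbon would separate the two.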